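The source may hold more compounds than are shown below. What is called first, only, known or untested is meant among the compounds shown, and "the series" means these compounds.

In a functional assay on A549 cells (Homo sapiens) for inhibition, read by CCK-8 assay, with a stated time of 72 h, tested at 2 uM (on this read-out higher numbers stand for more inhibition of growth at the one concentration tested and lower numbers for less inhibition of growth), compound 1 `COc1ccc(SCc2ccc(C(=O)Nc3ccccc3N)cc2)cc1` gives 45.7%, compound 2 `Nc1ccccc1NC(=O)c1ccc(CSc2ccc(Br)cc2)cc1` gives 33.2% and compound 3 `CC(C)(C)c1ccc(SCc2ccc(C(=O)Nc3ccccc3N)cc2)cc1` gives 38.6%. Compound 1 therefore stands clear of compound 2, with a number 12.5 percentage points lower from compound 1 to compound 2 (beyond the scatter), but not of compound 3, with a number 7.1 percentage points lower from compound 1 to compound 3 (within the scatter). Compound 4 `COc1ccc(SCc2ccc(C(=O)Nc3ccccc3N)cc2)cc1OC` carries methoxy in place of hydrogen on an aromatic carbon, ortho to a methoxy group (methoxy in place of hydrogen on an aromatic carbon). Both measured steps replace the existing methoxy of compound 1 and neither adds a group at this new place, so they are only loose guides. The larger of them is modest, so no step beyond the scatter is expected in this assay. The expected step is a number 2.7 percentage points lower from compound 1 to compound 4 (within the scatter). Compound 4 is expected at 43%, with an estimated range of 31% to 55%.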

Compound 4, percent growth inhibition at one concentration: 19.9%
Compound 4: the middle estimate sits 23.1 percentage points above what was measured; the measured number lies below the stated range.
By their numbers in this assay, from the lowest: compound 4; then compounds 2, 3 and 1 (each within the scatter of the next, the first and the last beyond it).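

In this assay, going by these compounds alone, the earlier steps only replaced the existing methoxy, whereas this change keeps it and adds a second methoxy on an aromatic carbon, ortho to a methoxy group, giving a number 25.8 percentage points lower from compound 1 to compound 4 (beyond the scatter). This position on the ring is therefore not indifferent to substitution, at least with methoxy entering on the core of compound 1. Nothing measured here explains the drop. As far as these compounds go, it remains open whether any group at this place lowers the number or only methoxy does. A fluorine atom, a methyl or a hydroxyl group here would help separate those two readings.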